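From propyl to ethyl on the amine: working notes

This account rests on a few compounds, and the source may have more. Where it says the series, first, only, none or still open, it means among the compounds named here.

compound 1 `CCCN(Cc1ccc(OCCN2C(=O)CCC2=O)c(C)c1)C(CC(=O)O)c1ccc(Cl)cc1`: 75%
compound 2 `CCCN(Cc1ccc(OCCN2C(=O)CCC2=O)c(C)c1)[C@H](CC(=O)O)c1ccc(Cl)cc1`: 69%

Both values come from an ADME assay on liver (Mus musculus) for metabolic stability, read by LC-MS, using microsomes and NADPH; a lower number here means that less of the compound is left, a higher number that more of the compound is left. Within the data shown here, compound 1 stands level with compound 2, the only other measured compound: the one measured step is a number 6 percentage points lower from compound 1 to compound 2 (within the scatter). Among the measured compounds shown here, the sole difference in that pair is the fact that one of compounds 1 and 2 is drawn with a defined configuration and the other without, at the place where they differ.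

Next in the series is compound 3 `CCN(Cc1ccc(OCCN2C(=O)CCC2=O)c(C)c1)C(CC(=O)O)c1ccc(Cl)cc1`. The change is hydrogen in place of methyl on a saturated chain carbon, two bonds along the chain from an amine nitrogen, so that propyl becomes ethyl. For the measured compounds named here, no measured step touches this chain. The step in configuration bears on it only indirectly, showing how close two compounds of the series can lie, and it gives no direction for the new change.

In this assay, no step beyond the scatter is therefore expected, and neither direction is favoured, though the range is kept wide for an untested change. The estimated step is a number 3 percentage points lower from compound 1 to compound 3 (within the scatter). Compound 3 is expected at 72%, with an estimated range from 57% to 86%.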

Compound 3, percent of the compound remaining: 88%
Compound 3: middle estimate off by 16 percentage points, on the low side, and the stated range ends below it.
By their numbers in this assay, from the lowest: compounds 2 and 1 (each within the scatter of the next); then compound 3.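

In this assay, shortening propyl to ethyl on the amine gives a clear result: a number 13 percentage points higher from compound 1 to compound 3 (beyond the scatter). The pair differs only by hydrogen in place of methyl on a saturated chain carbon, two bonds along the chain from an amine nitrogen, so this chain is a place where a single-carbon change can be read in this series. Among these compounds, it is also the first step here to lie beyond the scatter, whereas the earlier step in drawn configuration does not: a number 6 percentage points lower from compound 1 to compound 2 (within the scatter). Nothing in the available evidence bears on why the chain change moves the number; the only line at hand concerns configuration, not this chain, so the step stands as an observation without an explanation.

Still open, as far as these compounds go, is whether the direction holds further along the same line, with a methyl group or a bare hydrogen on the amine nitrogen, or whether it reverses with a branched chain such as isopropyl or a ring such as cyclopropyl. Also open, from the compounds shown here alone, is whether a single defined configuration of compound 3 would stay as close to compound 3 as compound 2 does to compound 1.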